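Swapping fluoro for iodo at the assay limit

A few compounds are considered here, and "the series" means these few. Any claim that something is new, unique, unknown or untested is made for them only; others in the source may bear on it.

Measured in a functional assay on A549 cells (Homo sapiens) for antiproliferative activity, read by MTT assay, with a stated time of 72 h; on this read-out higher numbers stand for weaker inhibition and lower numbers for stronger inhibition:
- compound 1 `C#Cc1cccc(Nc2ncnc3cc(OC)c(OCCCN4CCNCCNCC4)cc23)c1`: > 50000 nM
- compound 2 `COc1cc2ncnc(Nc3cccc(Cl)c3)c2cc1OCCCN1CCNCCNCC1`: > 50000 nM
- compound 3 `COc1cc2ncnc(Nc3cccc(F)c3)c2cc1OCCCN1CCNCCNCC1`: > 50000 nM

Compound 3 reads > 50000 nM, which is a limit of this assay and not a number. It has no readable place relative to the other two compounds, since the whole set rests on one mark: the limit of > 50000 nM in this assay, at which 3 of the 3 values shown sit.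

Compound 4 `COc1cc2ncnc(Nc3cccc(I)c3)c2cc1OCCCN1CCNCCNCC1` follows from compound 3 by one change, iodo in place of fluoro on an aromatic carbon, meta to a large group: iodo in place of fluoro on an aromatic carbon. In substituent terms, 3-fluorophenyl becomes 3-iodophenyl.

Going by the values given here, three measured steps bear on this change: a step that the two limits leave unreadable from compound 2 to compound 3, a step that the two limits leave unreadable from compound 1 to compound 2 and a step that the two limits leave unreadable from compound 1 to compound 3. None of them has a readable size, so they offer no direction for the new exchange. What they do show is that ethynyl, chloro and fluoro compounds all end at the limit, and iodo is expected to join them. The expected step, a number no higher from compound 3 to compound 4 (the limit leaves the size open), is therefore none beyond the scatter. A report of only a limit is the likeliest outcome. For compound 4 the estimate is 50000 nM, with an expected range of 20000 nM to 100000 nM.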

Compound 4, half-maximal inhibitory concentration: 26200 nM
Compound 4: the middle estimate sits 1.9-fold (0.28 log units) above what was measured, within the range that was stated.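

In this assay compound 4 gives a number, 26200 nM, so iodo, on an aromatic carbon meta to a large group, is the only one of the four groups shown that brings a reading at this place. Set against the other three groups, the result reads as an at least 1.9-fold lower number from compound 3 to compound 4 (0.28 log units; that floor lies within the scatter), an at least 1.9-fold lower number from compound 2 to compound 4 (0.28 log units; that floor lies within the scatter) and an at least 1.9-fold lower number from compound 1 to compound 4 (0.28 log units; that floor lies within the scatter), so these floors alone do not set iodo apart from fluoro, chloro or ethynyl beyond the scatter. The steps among compound 1, compound 2 and compound 3 cannot be read, and each floor stays open on its far side, since those three compounds share one mark, which is a limit and not a number: the limit of > 50000 nM in this assay, at which 3 of the 4 values shown sit.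

Whether a bromo group at this place would also give a number in this assay stays open, and the compounds shown do not tell how far the true gap to the fluoro, chloro and ethynyl compounds runs. Also open, as far as these compounds go, is whether the iodo compound would keep a reading with a longer chain or another amine in place of the one it carries.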